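A few compounds are considered here, and "the series" means these few. Any claim that something is new, unique, unknown or untested is made for them only; others in the source may bear on it.

Compound 1, `NS(=O)(=O)c1ccc(Nc2ncc(F)c(Nc3nc4ccccc4s3)n2)cc1`: in a functional assay on PC-3 cells (Homo sapiens) for antiproliferative activity, read by MTT assay, with a stated time of 48 h (a lower number here means a stronger inhibitor, a higher number a weaker inhibitor), compound 1 reaches only a limit, > 50000 nM.
Compound 2, `CS(=O)(=O)c1ccc(Nc2nccc(Nc3nc4ccccc4s3)n2)cc1`: in this assay compound 2 gives 1710 nM.
Compound 3, `COc1ccc2nc(Nc3ccnc(Nc4ccc(S(N)(=O)=O)cc4)n3)sc2c1`: in this assay compound 3 gives 3030 nM.

Three compounds share a core and differ in small attachments. Compound 1 sits at the limit of > 50000 nM in this assay, at which 1 of the 3 values shown sits, so it yields no number. Among the measured compounds shown here, of the two numbers that do exist, the one for compound 3 is the larger, yet the distance to compound 2 lies within the usual scatter of repeated runs, so no real difference between the two can be read from them.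

The step now followed goes from compound 3 to compound 4, `NS(=O)(=O)c1ccc(Nc2nccc(Nc3nc4ccccc4s3)n2)cc1`. The change is hydrogen in place of methoxy on an aromatic carbon. No pair of measured compounds shows exactly this change, so its effect is unknown from the numbers shown. Since compound 2, which also carries no methoxy, gives 1710 nM, and compound 3 gives 3030 nM, the expectation is a step of about a 1.2-fold lower number from compound 3 to compound 4 (0.08 log units; within the scatter), not beyond the scatter in either direction. Compound 4 is therefore estimated at 2500 nM, with a range from 800 nM to 8000 nM.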

Compound 4, half-maximal inhibitory concentration: 3100 nM
For compound 4 the middle estimate is 1.2-fold (0.09 log units) below the measured one; measured number inside the range.
By their numbers in this assay, from the lowest: compounds 2, 3 and 4 (each within the scatter of the next). At a limit, above all of these: compound 1.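

On the aromatic carbon of the fused ring system, methoxy and hydrogen cannot be told apart in this assay (a 1.0-fold higher number from compound 3 to compound 4 (0.01 log units; within the scatter)), and the same holds for amino in place of methyl on the sulfonyl sulfur (a 1.8-fold higher number from compound 2 to compound 4 (0.26 log units; within the scatter)), so neither of these two changes has a readable effect in this pair of comparisons. Among the compounds shown here, the one step beyond the scatter is hydrogen in place of fluoro on an aromatic carbon (an at least 16-fold lower number from compound 1 to compound 4 (1.20 log units; beyond the scatter)), which makes that carbon, among the places compared here, the only one where a change is seen to matter. The size of that step is only a bound, since compound 1 gives a limit and not a number: the limit of > 50000 nM in this assay, at which 1 of the 4 values shown sits.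

As far as these compounds go, it remains open whether a larger or differently built group on the carbon that carried methoxy, such as an amine, a carboxylic acid or a longer chain, would shift the number beyond the scatter. From the compounds shown here alone, it is also open whether chloro on the carbon that carries fluoro in compound 1 would give a similar result, and whether fluoro has the same effect when the sulfonyl sulfur carries methyl instead of amino.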